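The source may report more compounds than this note shows. Statements on the series, on what has been measured and on what is new or still open speak of the compounds shown alone.

Compound 1 `O=[N+]([O-])c1cc(-c2nc(N3CCN(c4ccccn4)CC3)no2)cc(O)c1O`: 32.2%
Compound 2 `O=[N+]([O-])c1cc(-c2cc(-c3cccnc3)no2)cc(O)c1O`: 33.6%

Both compounds share one core and were tested in a functional assay on the whole organism (liver, strain NMRI) for inhibition, with Mus musculus as the target, with a stated time of 3 h, at a dose of 3 mg/kg by the oral route; on this read-out higher numbers stand for more inhibition at the one dose given (going by the name of the read-out) and lower numbers for less inhibition. In that test compound 2 gives 33.6%, and compound 1 gives 32.2%; the two values lie within the usual scatter of each other, so no order between them can be read. Compound 3 `O=[N+]([O-])c1cc(-c2cc(-c3ccnc(F)c3)no2)cc(O)c1O` has not yet been measured. It differs from compound 2 in one place: 2-fluoropyridin-4-yl in place of pyridin-3-yl on an aromatic carbon. Going by the values given here, no measured pair shows what such a swap does, so the expected step of a number 2.6 percentage points lower from compound 2 to compound 3 (within the scatter) is small and could go either way, not beyond the scatter. Compound 3 is therefore estimated at 31%, with a range from 12% to 50%.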

Compound 3, a percentage reported as inhibition, in the whole organism at one dose (the size of the read-out at that dose, not a potency): 18.7%
Compound 3: the middle estimate sits 12.3 percentage points above what was measured, and the stated range covers the measured number.
By their numbers in this assay, from the lowest: compound 3; then compounds 1 and 2 (each within the scatter of the next).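

In this assay, 2-fluoropyridin-4-yl in place of pyridin-3-yl gives a number 14.9 percentage points lower from compound 2 to compound 3 (beyond the scatter) on this aromatic carbon of the five-membered ring. Going by these compounds alone, this is the first measured sign that the result responds to which ring sits at this position, since compound 1 and compound 2 alone offered no one-place comparison. Nothing here explains the fall.

Going by these compounds, the swap changes the ring's attachment and adds fluorine together, so their separate shares stay unknown. Plain pyridin-4-yl, or an amine in fluorine's place, would leave open whether the value of compound 2 can be kept.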